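Sulfamide for acetamide on the tetralin side chain

The source may hold more compounds than are shown below. What is called first, only, known or untested is meant among the compounds shown, and "the series" means these compounds.

Measured compounds:
compound 1 `O=C(NC[C@@H]1CCCc2cc(S(=O)(=O)c3cccc(F)c3)ccc21)[C@H]1CCCN1` — 0.631 nM
compound 2 `CC(=O)N(C)C[C@@H]1CCCc2cc(S(=O)(=O)c3cccc(F)c3)ccc21` — 1.59 nM

In an assay on isolated protein for displacement of a labelled ligand from 5-hydroxytryptamine receptor 6 (Homo sapiens) (a lower number here means a stronger inhibitor, a higher number a weaker inhibitor), compound 1 gives 0.631 nM and compound 2 gives 1.59 nM. Among the measured compounds shown here, compound 2 has the higher of the two numbers; the only step measured so far is a 2.5-fold higher number from compound 1 to compound 2 (0.40 log units; beyond the scatter), a modest but real change at the same position on the shared core.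

Compound 3 `NS(=O)(=O)NC[C@@H]1CCCc2cc(S(=O)(=O)c3cccc(F)c3)ccc21` differs from compound 2 by sulfamoylamino in place of acetyl(methyl)amino on a saturated chain carbon bound to a saturated ring carbon. For the measured compounds named here, no measured step swaps one group for another of this kind at that place, so the step from compound 1 to compound 2 is the only guide: it shows that a change of the group on the chain carbon shifts this assay by a modest amount in either direction. For compound 3 a step of similar or smaller size is expected, a 1.6-fold higher number from compound 2 to compound 3 (0.20 log units; within the scatter), without clear direction. Compound 3 is therefore estimated at 2.5 nM, within a range of 0.6 nM to 10 nM.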

Compound 3, inhibition constant: 0.126 nM
Estimate against measurement, compound 3: 20-fold (1.30 log units) above, outside the stated range (below it).
By their numbers in this assay, from the lowest: compound 3; then compound 1; then compound 2.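

In this assay, the group on the saturated chain carbon bound to a saturated ring carbon can shift the number much further than the first pair showed: sulfamoylamino in place of acetyl(methyl)amino gives a 13-fold lower number from compound 2 to compound 3 (1.10 log units; beyond the scatter), a large step. Sulfamoyl in place of (pyrrolidin-2-yl)carbonyl on an amine nitrogen points the same way, with a 5.0-fold lower number from compound 1 to compound 3 (0.70 log units; beyond the scatter), so compound 3 has the lowest number of the three, and both of its steps lie beyond the scatter. No measurement on hand accounts for this gain.

The step from acetyl(methyl)amino does not separate the loss of the methyl on nitrogen from the exchange of acetyl for sulfamoyl. Also open, on these data alone, is whether a urea or a methanesulfonylamino group at this place would hold the low number, or whether it is specific to sulfamoylamino.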